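The source may hold more compounds than are shown below. What is called first, only, known or untested is meant among the compounds shown, and "the series" means these compounds.

Compound 1 `COc1cc(-c2ccnc3cc(-c4ccccc4)nn23)cc(OC)c1OC` is the plainest of the three measured compounds: a shared core carrying a phenyl ring at one end. In a functional assay on B16-F0 cells (Mus musculus) for inhibition, read by CCK-8 assay, with a stated time of 48 h (on this read-out higher numbers stand for weaker inhibition and lower numbers for stronger inhibition), compound 1 gives 4730 nM, the highest of the three numbers. Compound 3 `COc1cc(-c2ccnc3cc(-c4cn(C(=O)OC(C)(C)C)c5ccccc45)nn23)cc(OC)c1OC`, with a substituted two-ring group in place of the phenyl, gives 3070 nM, a number within the scatter of compound 1, so no difference between them can be claimed. Compound 2 `COc1cc(-c2ccnc3cc(-c4ccc5c(ccn5C)c4)nn23)cc(OC)c1OC`, carrying a 1-methyl-1H-indol-5-yl group at the same place, gives 48 nM, and the step of a 99-fold lower number from compound 1 to compound 2 (1.99 log units; beyond the scatter) shows that a change at this position can move the read-out a great deal.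

Compound 4 `COc1ccc(-c2cc3nccc(-c4cc(OC)c(OC)c(OC)c4)n3n2)cc1N` keeps everything of compound 1 except the phenyl ring, which is exchanged as follows: 3-amino-4-methoxyphenyl in place of phenyl on an aromatic carbon. Within the data shown here, only the single step from compound 1 to compound 2 bears directly on this position, and it was large and toward stronger inhibition; compound 3 shows that not every replacement there helps. The entering 3-amino-4-methoxyphenyl is smaller than the groups in compounds 2 and 3, so the size of its effect is uncertain, but a clear move toward stronger inhibition is expected, of about a 59-fold lower number from compound 1 to compound 4 (1.77 log units; beyond the scatter). Compound 4 is therefore estimated at 80 nM, with a likely range from 10 nM to 600 nM.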

Compound 4, half-maximal inhibitory concentration: 88 nM
Compound 4: the middle estimate sits 1.1-fold (0.04 log units) below what was measured; low and high end bracket the measured number.
By their numbers in this assay, from the lowest: compounds 2 and 4 (each within the scatter of the next); then compounds 3 and 1 (each within the scatter of the next).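

The step of a 54-fold lower number from compound 1 to compound 4 (1.73 log units; beyond the scatter) shows that the large move toward stronger inhibition at this position in this assay does not need a two-ring group: a single six-membered aromatic ring of carbon, like the phenyl it replaces, is enough once it is a 3-amino-4-methoxyphenyl. The step of a 1.8-fold higher number from compound 2 to compound 4 (0.26 log units; within the scatter) stays within the scatter, so no difference between these two compounds can be claimed, and this read-out does not distinguish a 1-methyl-1H-indol-5-yl from a 3-amino-4-methoxyphenyl at this place. No outside measurement is available to explain either step.

The compounds shown do not separate the contribution of the amino group from that of the methoxy group, which a 3-aminophenyl or a 4-methoxyphenyl at the same place could do. From the compounds shown here alone, it also remains open how the read-out would respond if a hydroxyl or an acetamide took the place of the amino group on this ring.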